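The compounds below may be only part of what the source reports. "The series", "measured", "known", "first", "only" and "open" are said of these compounds alone.

Measured in an assay on isolated protein for inhibition of aldehyde dehydrogenase 1A1 (Homo sapiens), read by spectrophotometry, tested at 10 uM; on this read-out lower numbers stand for less inhibition and higher numbers for more inhibition at the one concentration tested (going by the name of the read-out):
- compound 1 `Cc1cccc(Cn2c(CN3CCN(C(=O)c4ccc(C(C)C)cc4)CC3)nc3ccccc32)c1`: 67.6%
- compound 2 `COc1cccc(Cn2c(CN3CCN(C(=O)C4CC4)CC3)nc3ccccc32)c1`: 44.4%
- compound 3 `Cc1ccc(Cn2c(CN3CCN(C(=O)C4CC4)CC3)nc3ccccc32)cc1`: 51.5%

Compound 1 stands highest of the three numbers; compound 3 lies nearest and compound 2 furthest below it, both gaps beyond the scatter. Compound 4 `Cc1ccc(C(=O)N2CCN(Cc3nc4ccccc4n3Cc3cccc(C)c3)CC2)cc1` differs from compound 1 in one place: methyl in place of isopropyl on an aromatic carbon on the (4-isopropylphenyl)carbonyl, giving (4-methylphenyl)carbonyl. Going by the values given here, the only measured step, a number 7.1 percentage points higher from compound 2 to compound 3 (within the scatter), concerns the other aryl group of the shared core, not the carbonyl-bearing ring, so no measured step bears directly on this change. With nothing to anchor it, the expectation is a modest loss relative to compound 1, near the edge of the scatter: a number 10.6 percentage points lower from compound 1 to compound 4 (beyond the scatter). Compound 4 is therefore estimated at 57%, within 42% to 72%.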

Compound 4, a percentage reported as inhibition, at one concentration (the size of the read-out at that concentration, not a potency): 64.9%
The estimate for compound 4 lay 7.9 percentage points below the measured number, within the range that was stated.
By their numbers in this assay, from the lowest: compounds 2 and 3 (each within the scatter of the next); then compounds 4 and 1 (each within the scatter of the next).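

In this assay, going by these compounds alone, methyl in place of isopropyl gives a number 2.7 percentage points lower from compound 1 to compound 4 (within the scatter) on the aromatic carbon of the carbonyl-bearing ring, a position the only earlier step did not touch. At this position, with the 3-methylbenzyl group of compounds 1 and 4 held constant, the read-out therefore does not separate 4-methylphenyl from 4-isopropylphenyl. Nothing available explains why these two groups read alike.

Open, on these data alone, is what a tert-butyl group, a methoxy group, a carboxylic acid or an amine would give at this position. Also open, as far as these compounds go, is whether the same change reads alike with another aryl group on the shared core.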